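Ester-to-acid step in the octylphenoxy tetrazole series

The source may hold more compounds than are shown below. What is called first, only, known or untested is meant among the compounds shown, and "the series" means these compounds.

Two members of the series have numbers in an assay on microsomes from brain for inhibition of Fatty-acid amide hydrolase 1 (Rattus norvegicus), read by fluorescence and HPLC, with a stated time of 60 min; on this read-out lower numbers stand for stronger inhibition and higher numbers for weaker inhibition. Compound 1 `CCCCCCCCc1ccc(OCC(=O)Cn2nnc(-c3ccc(C(=O)O)cc3)n2)cc1` gives 90 nM in this assay. Compound 2 `CCCCCCCCc1ccc(OC(C)C(=O)Cn2nnc(-c3ccc(C(=O)OC)cc3)n2)cc1` gives 25 nM in this assay, the lower of the two numbers; the gap from compound 1 lies beyond the scatter. These two compounds differ at more than one place, so the two values alone are what the pair shows.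

Compound 3 `CCCCCCCCc1ccc(OC(C)C(=O)Cn2nnc(-c3ccc(C(=O)O)cc3)n2)cc1` is not yet measured. Relative to compound 2 the change is hydrogen in place of methyl on an oxygen next to a carbonyl group, in words hydrogen in place of methyl on an oxygen next to a carbonyl group. Compound 3 thus carries the same carboxy group as compound 1 while keeping the rest of compound 2.

Among the compounds with values here, no step between measured compounds isolates this change. A loss of some size is expected, because compound 1, which also carries the carboxy group, gives 90 nM in this assay, though how much of that gap belongs to the ester is not resolved. The expected step of a 2.4-fold higher number from compound 2 to compound 3 (0.38 log units; beyond the scatter) is therefore a moderate rise, close to the edge of the scatter. Compound 3 is estimated at 60 nM, with a range of 20 nM to 180 nM.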

Compound 3, half-maximal inhibitory concentration: 50 nM
Estimate against measurement, compound 3: 1.2-fold (0.08 log units) above; low and high end bracket the measured number.
By their numbers in this assay, from the lowest: compounds 2, 3 and 1 (each within the scatter of the next, the first and the last beyond it).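

In this assay, the exchange of methoxycarbonyl for carboxy can now be read on its own: it gives a 2.0-fold higher number from compound 2 to compound 3 (0.30 log units; within the scatter), so the methyl ester and the free acid are not separated on this read-out in the context of compound 2. The second single change, methyl in place of hydrogen on the saturated chain carbon bound to a carbonyl carbon and an oxygen on an aromatic ring, gives a 1.8-fold lower number from compound 1 to compound 3 (0.26 log units; within the scatter), so the gap between compound 1 and compound 2, which lies beyond the scatter, divides into two steps that each lie within it. The compounds shown offer no independent measurement that would explain either step.

From the compounds shown here alone, what an ethyl ester or a primary amide would give in place of the carboxy group remains open, as does the effect of an ethyl group in place of the methyl on that chain carbon. Going by these compounds, it is also open whether these two steps would keep their size with a shorter chain in place of the octyl chain.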